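A fluorine added to the phenylethyl amide chain

The compounds below may be only part of what the source reports. "The series", "measured", "known", "first", "only" and "open" are said of these compounds alone.

Compound 1 `Cc1cc(C)cc(S(=O)(=O)c2c(C(=O)NCC(=O)NC(C)c3ccccc3)[nH]c3ccc(Cl)cc23)c1` carries a two-part amide chain that ends in a 1-phenylethyl group. In an ADME assay on MT4 cells (Homo sapiens) for cytotoxicity, read by MTT assay (a higher number here means that more compound is tolerated, a lower number that less compound is tolerated), compound 1 gives 29400 nM. Of the two compounds with a plain number, compound 1 has the higher one, though its neighbour compound 2 `Cc1cc(C)cc(S(=O)(=O)c2c(C(=O)NC(C)C(=O)NCc3ccco3)[nH]c3ccc(Cl)cc23)c1` sits close: compound 2 gives 24200 nM, and the step of a 1.2-fold lower number from compound 1 to compound 2 (0.08 log units; within the scatter) stays within the scatter. Compound 3 `Cc1cc(C)cc(S(=O)(=O)c2c(C(=O)NC(C)c3ccccc3F)[nH]c3ccc(Cl)cc23)c1`, which bears a 1-(2-fluorophenyl)ethyl group directly on the amide-type nitrogen, reaches only a limit of the assay, > 51500 nM. That reading for compound 3 is the limit of > 51500 nM in this assay, at which 1 of the 3 values shown sits. The step of an at least 1.7-fold higher number from compound 1 to compound 3 (0.24 log units; that floor lies within the scatter) combines two changes, and the step of an at least 2.1-fold higher number from compound 2 to compound 3 (0.32 log units; beyond the scatter) likewise; neither isolates the fluoro by itself.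

Compound 4 `Cc1cc(C)cc(S(=O)(=O)c2c(C(=O)NCC(=O)NC(C)c3ccccc3F)[nH]c3ccc(Cl)cc23)c1` differs from compound 1 in one place: fluoro in place of hydrogen on an aromatic carbon. The two measured steps that introduce the same fluoro both point toward a higher number, yet each also removes a piece of the chain, so for the fluoro alone only a small rise, if any, is expected, with a 1.2-fold higher number from compound 1 to compound 4 (0.09 log units; within the scatter). Compound 4 is therefore expected to give about 36000 nM, somewhere between 18000 nM and 72000 nM.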

Compound 4, half-maximal cytotoxic concentration: 23000 nM
The estimate for compound 4 lay 1.6-fold (0.19 log units) above the measured number, and the stated range covers the measured number.
By their numbers in this assay, from the lowest: compounds 4, 2 and 1 (each within the scatter of the next). At a limit, above all of these: compound 3.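

Among the compounds shown here, this pair is the first clean test of the fluoro. Compounds 1 and 4 differ only by fluoro in place of hydrogen on an aromatic carbon, ortho to a large group. In this assay, the change from phenyl to 2-fluorophenyl gives a 1.3-fold lower number from compound 1 to compound 4 (0.11 log units; within the scatter), so at this position the fluoro shows no clear effect on how much compound the cells tolerate. The data shown give no measured property that could explain this small step, and no cause can be assigned to it.

From the compounds shown here alone, compound 3 also carries the 1-(2-fluorophenyl)ethyl group but lacks part of the amide chain, and how much that difference matters stays open, as the reading for compound 3 is a limit, not a number: the limit of > 51500 nM in this assay, at which 1 of the 4 values shown sits. Also open, going by these compounds, is whether a larger or different group on the same aromatic carbon, such as a methoxy group or a nitrile, would stay as close to compound 1 as the fluoro does, since one small substituent at one position says little about the others.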